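Cyclohexyl in Place of Benzyl: An Expected Value

The source may hold more compounds than are shown below. What is called first, only, known or untested is meant among the compounds shown, and "the series" means these compounds.

Measured compounds:
Compound 1 `CC1=C(C(=O)OCc2ccccc2)C(c2ccco2)NC(=O)N1` — 36%
Compound 2 `CC1=C(C(=O)OCc2ccccc2)C(c2cccs2)NC(=O)N1` — 45%

In an assay on membranes from CHO cells for displacement of a labelled ligand from adenosine receptor A1 (Homo sapiens), read by scintillation counting, with a stated time of 60 min, tested at 1 uM (a higher number here means more inhibition at the concentration tested (going by the name of the read-out), a lower number less inhibition), compound 1 gives 36%, and compound 2 gives 45%. Compound 1 stands lowest of the two numbers, with compound 2 nearest; the step of a number 9 percentage points higher from compound 1 to compound 2 (within the scatter) lies within the scatter, so the two cannot be ordered against each other. That step comes from thiophen-2-yl in place of furan-2-yl on a saturated ring carbon.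

Compound 3 `CC1=C(C(=O)OC2CCCCC2)C(c2ccco2)NC(=O)N1` differs from compound 1 in another place: cyclohexyl in place of benzyl on an oxygen next to a carbonyl group. Among the compounds with values here, no measured step concerns this oxygen next to a carbonyl group; the only measured step, a number 9 percentage points higher from compound 1 to compound 2 (within the scatter), touches a different position and was itself within the scatter. There is thus no measured basis for a direction, and the expectation for compound 3 in this assay rests on compound 1 alone, with a wide range to reflect the lack of comparable steps. Compound 3 is therefore expected to give about 35%, between 10% and 60%. The expected step of a number 1 percentage points lower from compound 1 to compound 3 (within the scatter) is estimated to be no larger than the scatter.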

Compound 3, a percentage reported as inhibition, at one concentration (the size of the read-out at that concentration, not a potency): 1%
For compound 3 the middle estimate is 34 percentage points above the measured one; the whole stated range lies above it.
By their numbers in this assay, from the lowest: compound 3; then compounds 1 and 2 (each within the scatter of the next).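

In this assay, within the data shown here, this position proves sensitive where the earlier comparison showed nothing firm: cyclohexyl in place of benzyl on an oxygen next to a carbonyl group gives a number 35 percentage points lower from compound 1 to compound 3 (beyond the scatter), whereas the only earlier step, a number 9 percentage points higher from compound 1 to compound 2 (within the scatter), could not separate its two compounds. The change is a narrow one, since both groups are built of carbon only, each has one six-membered ring, and neither has hydrogen-bond donors, hydrogen-bond acceptors or a net charge; the ring of benzyl is aromatic and that of cyclohexyl is not. No available measurement bears on why the number falls so far with this exchange.

The compounds shown leave open whether the large step belongs to the aromatic ring itself, and whether a phenethyl group or a plain ethyl chain on the same oxygen would stand with compound 1 or with compound 3. They also leave open whether thiophen-2-yl in place of furan-2-yl would behave any differently with cyclohexyl on that oxygen than it does with benzyl.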